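Fluorophenyl in place of bromophenyl on the shared core

The source may hold more compounds than are shown below. What is called first, only, known or untested is meant among the compounds shown, and "the series" means these compounds.

Compound 1 `c1ccc(-c2cn3ccnc3c(-c3ccc4ncn(C5CCCCC5)c4c3)n2)cc1`: 51.6%
Compound 2 `CC(=O)c1ccc(-c2cn3ccnc3c(-c3ccc4ncn(C5CCCCC5)c4c3)n2)cc1`: 18.8%
Compound 3 `Brc1ccc(-c2cn3ccnc3c(-c3ccc4ncn(C5CCCCC5)c4c3)n2)cc1`: 35.8%

In a functional assay on HCT-15 cells (Homo sapiens) for inhibition, read by sulforhodamine B assay, with a stated time of 48 h, tested at 10 uM (a higher number here means more inhibition at the concentration tested (going by the name of the read-out), a lower number less inhibition), compound 3 stands second highest of the three values, between compound 1 and compound 2. Compound 4 `Fc1ccccc1-c1cn2ccnc2c(-c2ccc3ncn(C4CCCCC4)c3c2)n1` differs from compound 3 in one place: 2-fluorophenyl in place of 4-bromophenyl on an aromatic carbon. Two measured steps change the same phenyl ring: a number 15.8 percentage points lower from compound 1 to compound 3 (beyond the scatter) and a number 17 percentage points higher from compound 2 to compound 3 (beyond the scatter), while a number 32.8 percentage points lower from compound 1 to compound 2 (beyond the scatter). These show that a group on this ring moves the read-out by a modest to large amount, but none of them involves a fluorine or a change of position on the ring, so the direction for compound 4 is uncertain. Compound 4 is expected to give 44%, within 26% to 62%. This estimate means a step of a number 8.2 percentage points higher from compound 3 to compound 4 (within the scatter), expected to stay within the scatter.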

Compound 4, a percentage reported as inhibition, at one concentration (the size of the read-out at that concentration, not a potency): 6.18%
For compound 4 the middle estimate is 37.8 percentage points above the measured one; the whole stated range lies above it.
By their numbers in this assay, from the lowest: compound 4; then compound 2; then compound 3; then compound 1.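

In this assay, a single fluoro group on this phenyl ring is enough to lower the number, with a number 45.4 percentage points lower from compound 1 to compound 4 (beyond the scatter). Exchanging the groups gives a number 29.6 percentage points lower from compound 3 to compound 4 (beyond the scatter) and a number 12.6 percentage points lower from compound 2 to compound 4 (beyond the scatter), so every substituted ring shown now stands below the plain phenyl of compound 1, and no data here explain why. Because compound 3 and compound 4 differ in both the halogen and its ring position, the effects of these two changes cannot be separated. Going by these compounds, how an amine or a carboxylic acid on this ring would behave also remains open.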